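Clearance outlook for compound 4

This account rests on a few compounds, and the source may have more. Where it says the series, first, only, none or still open, it means among the compounds named here.

In an ADME assay (liver) for metabolic stability, with Liver microsome (Rattus norvegicus) as the target, using microsomes and NADPH, with a stated time of 30 min (on this read-out higher numbers stand for fast clearance and lower numbers for slow clearance), compound 1 `CC#C[C@H]1CN(S(=O)(=O)c2ccc(N)nc2)CCN1c1ccc(S(=O)(=NC)C(F)(F)F)cc1` gives 257 mL.min-1.g-1 as the highest number, while compound 2 `C#CCC(O)(c1ccc(N2CCN(S(=O)(=O)c3ccc(N)nc3)C[C@@H]2C#CC)cc1)C(F)(F)F` at 59 mL.min-1.g-1 and compound 3 `CC#C[C@H]1CN(S(=O)(=O)c2ccc(N)nc2)CCN1c1ccc(S(N)(=O)=O)cc1` at 30 mL.min-1.g-1 lie within the scatter of each other. The change to compound 4 `CC#C[C@H]1CN(S(=O)(=O)c2ccc(N)nc2)CCN1c1ccc(C(C)=O)cc1` is a group of 3 heavy atoms (2 carbon, 1 oxygen; no ring) in place of a group of 9 heavy atoms (5 carbon, 1 oxygen, 3 fluorine; no ring), on an aromatic carbon and the entering acetyl sits para to a large group. Three measured steps involve this aromatic carbon: a 4.4-fold lower number from compound 1 to compound 2 (0.64 log units; beyond the scatter) and an 8.6-fold lower number from compound 1 to compound 3 (0.93 log units; beyond the scatter) are both modest, whereas a 2.0-fold lower number from compound 2 to compound 3 (0.29 log units; within the scatter) stays within the scatter. Within the data shown here, no acetyl compound has been measured, so the expectation rests on this small set. The estimated change is a 1.1-fold higher number from compound 2 to compound 4 (0.04 log units; within the scatter) and thus none beyond the scatter. Compound 4 is estimated at 65 mL.min-1.g-1 in this assay with an expected range from 28 mL.min-1.g-1 to 150 mL.min-1.g-1 overall.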

Compound 4, intrinsic clearance in microsomes: 249 mL.min-1.g-1
Beside the measured number, compound 4's estimate is 3.8-fold (0.58 log units) below it; the measured number lies above the stated range.
By their numbers in this assay, from the lowest: compounds 3 and 2 (each within the scatter of the next); then compounds 4 and 1 (each within the scatter of the next).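

In this assay the acetyl change gives a 4.2-fold higher number from compound 2 to compound 4 (0.63 log units; beyond the scatter) and an 8.3-fold higher number from compound 3 to compound 4 (0.92 log units; beyond the scatter), whereas a 1.0-fold lower number from compound 1 to compound 4 (0.01 log units; within the scatter). Clearance at this aromatic carbon therefore does not follow heavy-atom count across these compounds: acetyl, the smallest group, groups with the much larger substituent of compound 1, not with the larger groups of compounds 2 and 3. Nothing available accounts for this grouping. As far as these compounds go, whether an amine, a carboxylic acid or a longer ketone chain at this carbon would group with compound 3 or with compound 4 remains open.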